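The source may report more compounds than this note shows. Statements on the series, on what has been measured and on what is new or still open speak of the compounds shown alone.

Series of benzyl-substituted chloropurines bearing a chloromethyl group on the benzyl ring, assessed in a functional assay on COLO 205 cells (Homo sapiens) for cytotoxicity, read by sulforhodamine B assay, with a stated time of 48 h; on this read-out higher numbers stand for weaker inhibition of growth and lower numbers for stronger inhibition of growth. Compound 1 `ClCc1cccc(Cn2cnc3c(Cl)ncnc32)c1` gives 10500 nM and so sits at the highest of the two numbers recorded; the nearest number belongs to compound 3 `ClCc1cccc(Cn2cnc3nc(Cl)nc(Cl)c32)c1`, which gives 1650 nM, a gap beyond the usual scatter. Compound 2 `ClCc1ccc(Cn2cnc3c(Cl)nc(Cl)nc32)cc1` returns only a limit of the assay, > 100000 nM, as noted in the limit of > 100000 nM in this assay, at which 1 of the 3 values shown sits. For the measured compounds named here, no pair among the measured compounds differs in a single place, so no measured step is available to anchor the next change.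

Compound 4 `Nc1nc(Cl)c2ncn(Cc3cccc(CCl)c3)c2n1` is not yet measured. It differs from compound 1 by amino in place of hydrogen on an aromatic carbon of the shared core. With no measured step of this kind in the set, the expectation for compound 4 is a change no larger than the scatter: an estimated step from compound 1 to compound 4 of a 1.3-fold lower number from compound 1 to compound 4 (0.12 log units; within the scatter). On that basis compound 4 is expected to give about 8000 nM, with a plausible range from 2000 nM to 40000 nM.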

Compound 4, concentration for total growth inhibition: 27500 nM
Estimate against measurement, compound 4: 3.4-fold (0.54 log units) below; the range from low to high includes it.
By their numbers in this assay, from the lowest: compound 3; then compound 1; then compound 4. At a limit, above all of these: compound 2.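

In this assay the series now has its first step between compounds that differ in one place: amino in place of hydrogen on an aromatic carbon, between two ring nitrogen atoms of the shared core, gives a 2.6-fold higher number from compound 1 to compound 4 (0.42 log units; beyond the scatter). This position is therefore not silent, as the change moves the read-out beyond the scatter towards weaker inhibition of growth, though only modestly. No measured property among the data bears on this step.

The compounds shown leave open whether the shift belongs to amino itself or to any group on this carbon, which methyl, methoxy or dimethylamino there would help to separate. Also open, from the compounds shown here alone, is whether amino gives a step of similar size on the other benzyl arrangements.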